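Swapping furan for pyridine on a shared core

The source may hold more compounds than are shown below. What is called first, only, known or untested is meant among the compounds shown, and "the series" means these compounds.

Measured compounds:
- Compound 1 `NS(=O)(=O)c1ccc(Nc2nccc(-c3ccncc3)n2)cc1`: 5100 nM
- Compound 2 `c1ccc(Nc2nccc(-c3ccncc3)n2)cc1`: 900 nM
- Compound 3 `CC1CCN(c2ccc(Nc3nccc(-c4ccco4)n3)cc2)CC1`: 1800 nM

All three were tested in a functional assay for inhibition, with Homo sapiens as the target; on this read-out lower numbers stand for stronger inhibition and higher numbers for weaker inhibition. Compound 3 stands second highest of the three numbers; its nearest neighbour is compound 2, whose value lies within the scatter of that of compound 3, while compound 1 gives a higher number that lies beyond the scatter. Going by the values given here, the one step between compounds differing in a single place is a 5.7-fold lower number from compound 1 to compound 2 (0.75 log units; beyond the scatter), which changes the group on the outer aromatic ring and says nothing about the ring that hangs from the core.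

Compound 4 `CC1CCN(c2ccc(Nc3nccc(-c4ccncc4)n3)cc2)CC1` differs from compound 3 in exactly that ring: pyridin-4-yl in place of furan-2-yl on an aromatic carbon. Among the compounds with values here, no measured pair changes this ring alone, so no step bears directly on it. Compounds 1 and 2 already carry pyridin-4-yl, and compound 2 sits within the scatter of compound 3, which is the only hint available. The expected step of a 1.2-fold lower number from compound 3 to compound 4 (0.08 log units; within the scatter) is therefore small, with no direction beyond the scatter. Compound 4 is estimated to give 1500 nM, within a range from 500 nM to 4500 nM.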

Compound 4, half-maximal inhibitory concentration: 600 nM
Estimate against measurement, compound 4: 2.5-fold (0.40 log units) above; the range from low to high includes it.
By their numbers in this assay, from the lowest: compounds 4, 2 and 3 (each within the scatter of the next, the first and the last beyond it); then compound 1.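

Measured in this assay the ring on the shared core now has its first direct comparison, and the swap of furan-2-yl for pyridin-4-yl gives a step beyond the scatter (a 3.0-fold lower number from compound 3 to compound 4 (0.48 log units; beyond the scatter)), so this position does register a change, at least with 4-methylpiperidin-1-yl on the outer ring. The outer ring can also be read more closely: with pyridin-4-yl in place, 4-methylpiperidin-1-yl in place of hydrogen stays within the scatter (a 1.5-fold lower number from compound 2 to compound 4 (0.18 log units; within the scatter)), while the same group in place of sulfamoyl lies beyond it (an 8.5-fold lower number from compound 1 to compound 4 (0.93 log units; beyond the scatter)), which leaves compound 1 apart from both compound 2 and compound 4. Nothing available explains why these numbers differ.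

As far as these compounds go, the ring swap is seen on only one outer-ring background, so it remains open whether pyridin-4-yl and furan-2-yl would differ the same way with hydrogen or sulfamoyl on that ring. From the compounds shown here alone, it is also open how a plain phenyl ring or pyridin-3-yl would fare at this position, or how an amine or a carboxylic acid would fare on the outer ring.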